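Saturation of one chain double bond in a polyphenol series

A few compounds are considered here, and "the series" means these few. Any claim that something is new, unique, unknown or untested is made for them only; others in the source may bear on it.

Measured compounds:
- Compound 1 `CCCCC/C=C\C/C=C\CCCCCCCc1cc(=O)c2c(O)c(C)c(OCOC)c(C)c2o1`: > 84100 nM in a functional assay on MCF7 cells (Homo sapiens) for antiproliferative activity, read by MTT assay; on this read-out lower numbers stand for stronger inhibition and higher numbers for weaker inhibition
- Compound 2 `CC/C=C\C/C=C\C/C=C\CCCCCCCc1cc(=O)c2c(O)c(C)c(OCOC)c(C)c2o1`: > 84100 nM
- Compound 3 `CC/C=C\C/C=C\C/C=C\CCCCCCCC1(O)CC(=O)c2c(O)cc(O)cc2O1`: 17500 nM

The value of compound 1 in this assay is a limit of the assay, not a number. The value of compound 2 is likewise a limit. Among the compounds with values here, compound 3 gives the only number among the three. Compounds 1 and 2 share one core and differ by butyl in place of but-1-en-1-yl on a saturated chain carbon bound to a double-bonded chain carbon; the size of that step is a step that the two limits leave unreadable from compound 2 to compound 1, because the limit of > 84100 nM in this assay, at which 2 of the 3 values shown sit, holds both of them. The difference between the core of compound 3 and the core of compound 2 is not broken down here.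

Compound 4 `CCCCC/C=C\C/C=C\CCCCCCCC1(O)CC(=O)c2c(O)cc(O)cc2O1` has not yet been measured. Relative to compound 3 it carries butyl in place of but-1-en-1-yl on a saturated chain carbon bound to a double-bonded chain carbon, the same change as from compound 2 to compound 1. Since that earlier step is unreadable, nothing measured fixes its size; the expectation for compound 4 therefore rests on the number of compound 3, 17500 nM, and is a step of a 1.1-fold higher number from compound 3 to compound 4 (0.06 log units; within the scatter), a change about as large as repeated measurement would show. Compound 4 is estimated at 20000 nM, with a range from 6000 nM to 70000 nM.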

Compound 4, half-maximal inhibitory concentration: 17500 nM
The estimate for compound 4 lay 1.1-fold (0.06 log units) above the measured number; the measured number falls inside the stated range.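

In this assay, butyl in place of but-1-en-1-yl gives no change at the digits printed from compound 3 to compound 4 (within the scatter), so on this core, removing that one chain double bond leaves the number where it stood. On the other core the same change cannot be read, because the values of compound 1 and compound 2 are both limits of the assay, not numbers: the limit of > 84100 nM in this assay, at which 2 of the 4 values shown sit. The change is therefore read on one core only, and nothing here shows whether it would behave the same way on the core of compound 1.

Still open, on these data alone, is how a fully saturated chain would read on either core. Also open, as far as these compounds go, is what a chain carrying a carboxylic acid or an amine would give in this assay.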